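Notes on compound 4: a further chloro added to compound 1

The source may report more compounds than this note shows. Statements on the series, on what has been measured and on what is new or still open speak of the compounds shown alone.

Measured in a functional assay on HL-60 cells (Homo sapiens) for inhibition, read by MTT assay, with a stated time of 72 h; on this read-out higher numbers stand for weaker inhibition and lower numbers for stronger inhibition:
compound 1 `Cc1nc(-c2ccc(F)cc2)c(C(=O)N2CCN(c3cccc(Cl)c3)CC2)o1` gives 40.1 nM
compound 2 `Cc1nc(-c2cccc(O)c2)c(C(=O)N2CCN(c3cccc(Cl)c3)CC2)o1` gives 105 nM
compound 3 `Cc1nc(-c2ccccc2Cl)c(C(=O)N2CCN(c3cccc(Cl)c3)CC2)o1` gives 132 nM

Compound 1 stands lowest of the three numbers shown; the steps of a 2.6-fold higher number from compound 1 to compound 2 (0.42 log units; beyond the scatter) and a 3.3-fold higher number from compound 1 to compound 3 (0.52 log units; beyond the scatter) lie beyond the scatter, whereas a 1.3-fold higher number from compound 2 to compound 3 (0.10 log units; within the scatter) does not. Compound 4 `Cc1nc(-c2ccc(F)cc2)c(C(=O)N2CCN(c3cc(Cl)cc(Cl)c3)CC2)o1` differs from compound 1 by chloro in place of hydrogen on an aromatic carbon. Among the measured compounds shown here, none of the three measured steps touches this part of the shared core: all of them replace the 4-fluorophenyl of compound 1 or compare its replacements with each other, so no measured step bears on the change. Without a guide, a step of no size beyond the scatter is expected from compound 1 to compound 4, a 1.1-fold higher number from compound 1 to compound 4 (0.05 log units; within the scatter). Compound 4 is therefore estimated at 45 nM in this assay, within 18 nM to 115 nM.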

Compound 4, half-maximal inhibitory concentration: 52.1 nM
For compound 4 the middle estimate is 1.2-fold (0.06 log units) below the measured one; the measured number falls inside the stated range.
By their numbers in this assay, from the lowest: compounds 1, 4, 2 and 3 (each within the scatter of the next, the first and the last beyond it).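

In this assay, the only change shown on the 3-chlorophenyl side of the molecule, 3-chlorophenyl to 3,5-dichlorophenyl, gives a 1.3-fold higher number from compound 1 to compound 4 (0.11 log units; within the scatter). This position therefore accepts a second chloro without a step beyond the scatter, whereas all earlier steps concerned the 4-fluorophenyl. No evidence at hand accounts for the size of this step.

As far as these compounds go, it remains open whether a methoxy, an amine or a carboxylic acid at this position would leave the number as little moved. From the compounds shown here alone, it is also open whether the added chloro gives a similar step alongside the 3-hydroxyphenyl of compound 2 or the 2-chlorophenyl of compound 3.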